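The source may hold more compounds than are shown below. What is called first, only, known or untested is meant among the compounds shown, and "the series" means these compounds.

Measured compounds and their values in a functional assay on DU-145 cells (Homo sapiens) for antiproliferative activity, read by propidium iodide staining, with a stated time of 96 h; on this read-out higher numbers stand for weaker inhibition and lower numbers for stronger inhibition:
compound 1, `CC(O)(COc1ccc(C#N)cc1)C(=O)Nc1ccc(S(F)(F)(F)(F)F)cc1`: 32200 nM
compound 2, `CC(O)(COc1ccc(C#N)c(F)c1)C(=O)Nc1ccc(S(F)(F)(F)(F)F)cc1`: 30400 nM
compound 3, `CC(O)(COc1ccc(C#N)cc1)C(=O)Nc1cccc(S(F)(F)(F)(F)F)c1`: 42600 nM

All three sit close together in this assay, and none of the gaps between them exceeds the usual scatter. Compound 1 and compound 2 share a core and differ in one place: fluoro in place of hydrogen on an aromatic carbon. That change produced a 1.1-fold lower number from compound 1 to compound 2 (0.02 log units; within the scatter), so here it left the read-out essentially unchanged. Compound 3 carries a different core; how the core of compound 3 differs from the core of compound 1 is not broken down here, and their two values lie within the scatter of each other.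

Compound 4, `CC(O)(COc1ccc(C#N)c(F)c1)C(=O)Nc1cccc(S(F)(F)(F)(F)F)c1`, has not yet been measured in this assay. It stands to compound 3 as compound 2 stands to compound 1: fluoro in place of hydrogen on an aromatic carbon. The place of the change is described in the same words for both pairs, so this is the same change made on the other core. Because the earlier step was a 1.1-fold lower number from compound 1 to compound 2 (0.02 log units; within the scatter), the step from compound 3 to compound 4 is expected to be small as well, roughly a 1.1-fold lower number from compound 3 to compound 4 (0.03 log units; within the scatter). For compound 4 the estimate is therefore 40000 nM, with a plausible range from 20000 nM to 80000 nM.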

Compound 4, half-maximal inhibitory concentration: 74800 nM
Compound 4: middle estimate off by 1.9-fold (0.27 log units), on the low side, within the range that was stated.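

In this assay, fluoro in place of hydrogen on the core of compound 3, ortho to a cyano group, gave a 1.8-fold higher number from compound 3 to compound 4 (0.24 log units; within the scatter). Set beside the same change on the core of compound 1, the two steps cannot be told apart: the same change on two cores in this assay, a 1.1-fold lower number (0.02 log units; within the scatter) from compound 1 to compound 2 and a 1.8-fold higher number (0.24 log units; within the scatter) from compound 3 to compound 4, 1.9-fold (0.27 log units) apart, within the scatter of two such steps. Within the data shown here, this shows that, in these two pairs, the change from 4-cyanophenyl to 4-cyano-3-fluorophenyl produced no step beyond the scatter on either core, but it does not show that the change is without effect in general, and with only two pairs, it does not establish a rule for other cores or show whether the two steps truly differ in direction.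

The compounds shown leave open whether a chloro or methoxy group on the same aromatic carbon would give a step beyond the scatter. They also leave open what a carboxylic acid or an amine in place of the nitrile would do on either core.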